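The source may report more compounds than this note shows. Statements on the series, on what has been measured and on what is new or still open speak of the compounds shown alone.

In an assay on J774 cells for inhibition of prostaglandin G/H synthase 1 (Mus musculus), read by immunoassay, with stated times of 15 min and 30 min (on this read-out higher numbers stand for weaker inhibition and lower numbers for stronger inhibition), compound 1, `Cc1c(C=O)cc(-c2ccc(S(C)(=O)=O)cc2)n1-c1ccc(F)c(F)c1`, gives > 10000 nM, which is a limit of the assay rather than a measured number. Compound 2, `Cc1c(/C=N\O)cc(-c2ccc(S(C)(=O)=O)cc2)n1-c1ccc(F)cc1`, gives > 10000 nM in this assay, and this too is a limit. Compound 3, `Cc1c(/C=N\O)cc(-c2ccc(S(C)(=O)=O)cc2)n1-c1cccc(F)c1`, gives > 10000 nM in this assay, again only a limit. Compound 3 therefore stands among three values of which none is a real number, and the step from compound 2 to compound 3, a step that the two limits leave unreadable from compound 2 to compound 3, cannot be read in either direction. Every value shown sits at the limit of > 10000 nM in this assay, at which 3 of the 3 values shown sit.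

Compound 4, `Cc1c(/C=N\O)cc(-c2ccc(S(C)(=O)=O)cc2)n1-c1ccc(F)c(F)c1`, is reached from compound 3 by fluoro in place of hydrogen on an aromatic carbon. Going by the values given here, the one step measured so far is unreadable, so it gives no size or direction to carry over. What the data do offer is compound 1, which already carries the 3,4-difluorophenyl on the aromatic nitrogen and gives > 10000 nM, a limit. On that basis compound 4 is expected to remain at the limit as well, with an expected step that the limit leaves unreadable from compound 3 to compound 4 that cannot be distinguished from no change. The estimate for compound 4 in this assay is 20000 nM, between 8000 nM and 60000 nM, most likely reported as a limit.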

Compound 4, half-maximal inhibitory concentration: > 10000 nM
Compound 4: no number, only a limit (the forecaster's own chance of this, stated with the estimate: 85%); the middle value does not contradict the limit.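

No new step can be read among compound 1, compound 2, compound 3 and compound 4, because each gives only a limit of the assay and not a real number: the limit of > 10000 nM in this assay, at which 4 of the 4 values shown sit.

The compounds shown leave open how strongly any of them inhibits this enzyme, and whether any of the changes among them alters that inhibition at all.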